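This account rests on a few compounds, and the source may have more. Where it says the series, first, only, none or still open, it means among the compounds named here.

Compound 1 `O=C(CCC1CCCCC1)Nc1ncc(Cc2cccc3sccc23)s1` in an ADME assay on P388D1 cells (Mus musculus) for cytotoxicity, read by fluorescence and resazurin assay, with a stated time of 72 h (on this read-out lower numbers stand for stronger inhibition and higher numbers for weaker inhibition), gives > 40000 nM, a limit of the assay.
Compound 2 `O=C(Nc1ncc(Cc2cccc3sccc23)s1)C1CCCCC1` in this assay gives > 40000 nM, again a limit.
Compound 3 `O=C(Nc1ncc(Cc2cccc3ccccc23)s1)C1CCCCC1` in this assay gives > 40000 nM, likewise a limit.

The cores of compound 2 and compound 3 differ, but that difference is not broken down here. From compound 2 to compound 1 the change is 2-cyclohexylethyl in place of cyclohexyl on a carbonyl carbon; the step that the two limits leave unreadable from compound 2 to compound 1 cannot be read, because of the limit of > 40000 nM in this assay, at which 3 of the 3 values shown sit. The same change, (2-cyclohexylethyl in place of cyclohexyl on a carbonyl carbon), turns compound 3 into compound 4 `O=C(CCC1CCCCC1)Nc1ncc(Cc2cccc3ccccc23)s1`, with the place being the same in both pairs.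

Since all three measured values sit at the limit, compound 4 is expected to stay at or past it in this assay, an expected step that the limit leaves unreadable from compound 3 to compound 4 from compound 3. The estimate for compound 4 is 60000 nM, expected between 30000 nM and 150000 nM, most likely reported only as a limit.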

Compound 4, half-maximal inhibitory concentration: 27600 nM
For compound 4 the middle estimate is 2.2-fold (0.34 log units) above the measured one; the whole stated range lies above it.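

In this assay, 2-cyclohexylethyl in place of cyclohexyl on the carbonyl carbon gives an at least 1.4-fold lower number from compound 3 to compound 4 (0.16 log units; that floor lies within the scatter). Within the data shown here, compound 4 gives 27600 nM, the only value shown that is not a limit. The floor of the step stays within the scatter, so a real change is not established. The same change from compound 2 to compound 1 cannot be read, and so carry-over between the two cores can be neither confirmed nor ruled out: the limit of > 40000 nM in this assay, at which 3 of the 4 values shown sit.

Open, as far as these compounds go, is whether a longer chain in place of 2-cyclohexylethyl would give readable values on both cores in this assay. Also open, from the compounds shown here alone, is how an amine or a carboxylic acid in place of the cyclohexyl ring would read there.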